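The source may report more compounds than this note shows. Statements on the series, on what has been measured and on what is new or still open speak of the compounds shown alone.

Measured so far in a functional assay, read by spectrophotometry, with a stated time of 3 min; a lower number here means a stronger inhibitor, a higher number a weaker inhibitor:

- compound 1 `NS(=O)(=O)CC(=O)N/N=C/c1cc2ccccc2[nH]c1=O`: 8910 nM
- compound 2 `O=c1[nH]c2ccccc2cc1/C=N/Nc1ccc([N+](=O)[O-])cc1`: 11400 nM
- compound 3 `Cc1ccc2[nH]c(=O)c(/C=N/Nc3ccccc3)cc2c1`: 8470 nM

All three share the same core with a hydrazone attached to it and differ only in what hangs off the hydrazone and in the substituent on the core. Compound 3 gives the lowest of the three numbers in this assay, but the gap to compound 1 and the gap to compound 2 both fall within the scatter, so the three compounds cannot be told apart on these data.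

Compound 4 `O=c1[nH]c2ccccc2cc1/C=N/Nc1ccccc1` is the unmeasured partner of compound 3. The single difference is hydrogen in place of methyl on an aromatic carbon of a six-membered aromatic ring of carbon only, meta to a fused ring and para to a fused ring. Within the data shown here, no pair of measured compounds tests a change of this kind, so there is no reference step.

With a change this small, the expected step of a 1.2-fold higher number from compound 3 to compound 4 (0.09 log units; within the scatter) in this assay is none beyond the scatter, leaning if at all toward a slightly higher number. Compound 4 is therefore estimated at 10500 nM in this assay, with a range of 4500 nM to 25000 nM.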

Compound 4, half-maximal inhibitory concentration: 11800 nM
For compound 4 the middle estimate is 1.1-fold (0.05 log units) below the measured one; low and high end bracket the measured number.
By their numbers in this assay, from the lowest: compounds 3, 1, 2 and 4 (each within the scatter of the next).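

In this assay hydrogen in place of methyl on an aromatic carbon, meta to a fused ring and para to a fused ring, gives a 1.4-fold higher number from compound 3 to compound 4 (0.14 log units; within the scatter) and so does not separate the two groups at this position of the shared core. Hydrogen in place of nitro on an aromatic carbon gives a 1.0-fold higher number from compound 2 to compound 4 (0.01 log units; within the scatter) and phenyl in place of (sulfamoylmethyl)carbonyl on an amine nitrogen gives a 1.3-fold higher number from compound 1 to compound 4 (0.12 log units; within the scatter) so compound 4 links all three earlier compounds by single changes, none of which moves the number beyond the scatter. Nothing measured here bears on why these changes leave the number where it is.

Still open, going by these compounds, is whether an amine or a carboxylic acid on that aromatic carbon, or a longer chain in place of phenyl on the amine nitrogen, would move the number beyond the scatter. Also open, on these data alone, is whether the same picture holds in any read-out other than this assay for these compounds.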